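Adding a hydroxymethyl to compound 1

The source may report more compounds than this note shows. Statements on the series, on what has been measured and on what is new or still open speak of the compounds shown alone.

Measured so far in an ADME assay on HEK-293T cells (Homo sapiens) for cytotoxicity, read by luminescence, with a stated time of 24 h; a higher number here means that more compound is tolerated, a lower number that less compound is tolerated
- Compound 1 `CCCNC(=O)C1CCN(C(=O)c2cc3sccc3n2Cc2ccc(OC)cc2)CC1` gives 18800 nM
- Compound 2 `CCCNC(=O)C1CCN(C(=O)c2cc3sc(Br)cc3n2Cc2ccc(OC)cc2)CC1` gives > 100000 nM (a limit of the assay, not a number)

For the measured compounds named here, compound 1 sits at 18800 nM as the only exact number available, so there is no spread of values to place it in. Compound 2 reached > 100000 nM as a limit of the assay.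

Compound 3 `CCCNC(=O)C1CCN(C(=O)c2c(CO)c3sccc3n2Cc2ccc(OC)cc2)CC1` comes from compound 1 by a single change, hydroxymethyl in place of hydrogen on an aromatic carbon on the shared core.

Going by the values given here, only one measured step bears on this, and only loosely. It is an at least 5.3-fold higher number from compound 1 to compound 2 (0.72 log units; beyond the scatter) and is beyond the scatter, but it concerns bromo in place of hydrogen on another aromatic carbon. It shows that one small change to the core can shift this number upward, yet it cannot give the size for a different group. A small upward step is therefore expected, probably within the scatter. The expected change is a 1.5-fold higher number from compound 1 to compound 3 (0.17 log units; within the scatter) as a rough estimate. For compound 3 the estimated value is 28000 nM with an expected range from 9000 nM to 90000 nM in this assay.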

Compound 3, half-maximal cytotoxic concentration: > 100000 nM
Compound 3: no number, only a limit (the forecaster's own chance of this, stated with the estimate: 12%); middle value at least 3.5-fold (0.55 log units) away from the limit.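

In this assay, hydroxymethyl in place of hydrogen on an aromatic carbon gives an at least 5.3-fold higher number from compound 1 to compound 3 (0.72 log units; beyond the scatter), which means that more compound is tolerated after this change. Compound 2 had shown such a rise for bromo on another aromatic carbon, whereas this result shows that the number also responds to a change at a second place on the shared core, on the five-membered aromatic ring with 1 nitrogen. The full size of this step stays unknown, because compound 3 gives a limit of the assay and not a number: the limit of > 100000 nM in this assay, at which 2 of the 3 values shown sit.

The compounds shown leave open whether this rise depends on the hydroxymethyl group itself or would also appear with another group in the same place, such as a methyl, an amine or a carboxylic acid. A longer chain ending in a hydroxyl, such as hydroxyethyl, could show whether the length of the group matters, although a result that also reached the limit of this assay would not settle that.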